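The compounds below may be only part of what the source reports. "The series", "measured", "known", "first", "only" and "open" are said of these compounds alone.

Measured so far: compound 1 `CC(=O)Oc1ccccc1C(=O)O[C@H]1CO[C@H]2[C@@H]1OC[C@H]2O` gives 0.0183 h in an ADME assay on a cell-free system (plasma, Homo sapiens) for metabolic stability, with Plasma (Rattus norvegicus) as the target, read by HPLC, at pH 7.4; on this read-out higher numbers stand for a longer-lived compound and lower numbers for a shorter-lived compound; compound 2 `CC(=O)Oc1ccccc1C(=O)O[C@H]1CO[C@H]2[C@@H]1OC[C@H]2OC(=O)C1CC1` gives 0.015 h; compound 3 `CC(=O)Oc1ccccc1C(=O)O[C@H]1CO[C@H]2[C@@H]1OC[C@H]2OC(=O)c1ccccc1OC(=O)c1ccccc1` gives 0.0722 h.

Compound 2 holds the lowest number of the three in this assay, though compound 1 sits within the scatter of it, while compound 3 shows a clearly higher value. Going by the values given here, the only step with one change, a 1.2-fold lower number from compound 1 to compound 2 (0.09 log units; within the scatter), lies within the scatter. Compound 4 `CCOc1cc(OCC)cc(C(=O)O[C@@H]2CO[C@H]3[C@@H]2OC[C@@H]3OC(=O)c2ccccc2OC(C)=O)c1` differs from compound 2 in one place: 3,5-diethoxyphenyl in place of cyclopropyl on a carbonyl carbon. Among the compounds with values here, no measured step covers this change directly; compound 3, which also carries an aromatic ester on that oxygen, gives the highest number, so a modest rise is expected. Compound 4 is therefore estimated at 0.04 h (range 0.015 h to 0.11 h), a step of a 2.7-fold higher number from compound 2 to compound 4 (0.43 log units; beyond the scatter).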

Compound 4, half-life: 0.0283 h
Estimate against measurement, compound 4: 1.4-fold (0.15 log units) above; low and high end bracket the measured number.
By their numbers in this assay, from the lowest: compounds 2, 1 and 4 (each within the scatter of the next); then compound 3.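

In this assay the exchange of cyclopropyl for 3,5-diethoxyphenyl on this carbonyl carbon gives a 1.9-fold higher number from compound 2 to compound 4 (0.28 log units; within the scatter) and so does not separate the larger aromatic group from the small ring. An aromatic ring at this place is thus not enough on its own to give a number beyond the scatter of compound 2, and only compound 3 shows such a gap. Nothing measured here explains this result. Going by these compounds, whether a longer chain, or an amine on that chain, would move the half-life beyond the scatter remains open.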